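Working notes: from compound 2 to compound 4

The source may report more compounds than this note shows. Statements on the series, on what has been measured and on what is new or still open speak of the compounds shown alone.

Measured in a functional assay on NCI-H460 cells (Homo sapiens) for cytotoxicity, read by MTT assay, with a stated time of 96 h; a lower number here means a stronger inhibitor, a higher number a weaker inhibitor:
- compound 1 `COc1ncc(-c2cc(OC)c3nc(N)nc(C)c3c2)cc1NS(=O)(=O)c1ccc(F)cc1F` gives 280 nM
- compound 2 `COc1ncc(-c2cc(OC(C)C)c3nc(N)nc(C)c3c2)cc1NS(=O)(=O)c1ccc(F)cc1F` gives 140 nM
- compound 3 `COCCOc1cc(-c2cnc(OC)c(NS(=O)(=O)c3ccc(F)cc3F)c2)cc2c(C)nc(N)nc12` gives 200 nM

Compound 2 stands at 140 nM and lies within the scatter of both other compounds, with steps of a 2.0-fold lower number from compound 1 to compound 2 (0.30 log units; within the scatter) and a 1.4-fold higher number from compound 2 to compound 3 (0.15 log units; within the scatter) as measured. Compound 4 `COc1ncc(-c2cc(OC3CCN(C)CC3)c3nc(N)nc(C)c3c2)cc1NS(=O)(=O)c1ccc(F)cc1F` carries 1-methylpiperidin-4-yl in place of isopropyl on an oxygen on an aromatic ring. Those two steps and a 1.4-fold lower number from compound 1 to compound 3 (0.15 log units; within the scatter) as well change the group on that same oxygen, and none exceeds the scatter. For the measured compounds named here, no measured compound has a ring in that group, so this evidence is limited. On that basis, no step beyond the scatter is expected in this assay. The expected step is a 1.1-fold higher number from compound 2 to compound 4 (0.03 log units; within the scatter) as estimated here. Compound 4 is estimated at 150 nM (range 50 nM to 450 nM).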

Compound 4, half-maximal inhibitory concentration: 660 nM
Compound 4: the middle estimate sits 4.4-fold (0.64 log units) below what was measured; measured number above the stated range.
By their numbers in this assay, from the lowest: compounds 2, 3 and 1 (each within the scatter of the next); then compound 4.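

In this assay this oxygen on an aromatic ring shows its first step beyond the scatter: the change to 1-methylpiperidin-4-yl brings a 4.7-fold higher number from compound 2 to compound 4 (0.67 log units; beyond the scatter) and a 3.3-fold higher number from compound 3 to compound 4 (0.52 log units; beyond the scatter) and also a 2.4-fold higher number from compound 1 to compound 4 (0.37 log units; beyond the scatter) in the same direction. Methyl, isopropyl and 2-methoxyethyl remain within the scatter of one another, so the group here is not freely exchangeable. The ring and the nitrogen enter together, and nothing at hand accounts for the step.

Going by these compounds, whether the ring or the nitrogen carries the step remains open. A 2-(dimethylamino)ethyl chain on this oxygen, an amine without a ring, would separate the two.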